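A few compounds are considered here, and "the series" means these few. Any claim that something is new, unique, unknown or untested is made for them only; others in the source may bear on it.

Measured in a functional assay on HCT-116 cells (Homo sapiens) for inhibition, read by CCK-8 assay, with a stated time of 72 h, tested at 2 uM; a lower number here means less inhibition of growth, a higher number more inhibition of growth at the concentration tested:
- compound 1 `Nc1ccccc1NC(=O)c1ccc(CSc2cccc(F)c2)cc1`: 5.5%
- compound 2 `Cc1ccc(SCc2ccc(C(=O)Nc3ccccc3N)cc2)cc1`: 74.8%
- compound 3 `Nc1ccccc1NC(=O)c1ccc(CSCCc2ccccc2)cc1`: 30.5%

Compound 3 holds the middle place of the three. Its two neighbours are set by a number 25 percentage points higher from compound 1 to compound 3 (beyond the scatter) and by a number 44.3 percentage points lower from compound 2 to compound 3 (beyond the scatter).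

The next change leads to compound 4 `Nc1ccccc1NC(=O)c1ccc(CSc2ccc(F)cc2)cc1`, with 4-fluorophenyl in place of phenethyl on a sulfur.

The same two steps bear on this change, read in reverse, since each also exchanges phenethyl for a substituted phenyl. They point in opposite directions, so they fix no direction for compound 4. The swap between the two substituted phenyl groups is also wide, at a number 69.3 percentage points higher from compound 1 to compound 2 (beyond the scatter), so the outcome depends heavily on the group chosen. Compound 4 resembles compound 1 in carrying fluorine and compound 2 in the place of its substituent, as the names 4-fluorophenyl and 4-methylphenyl show, and the data do not separate these two resemblances.

The expected outcome is a number 9.5 percentage points higher from compound 3 to compound 4 (within the scatter), and its direction is only weakly held.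

Compound 4 is estimated at 40%, with an expected range from 12% to 72%.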

Compound 4, percent growth inhibition at one concentration: 13.5%
Estimate against measurement, compound 4: 26.5 percentage points above; the range from low to high includes it.
By their numbers in this assay, from the lowest: compounds 1 and 4 (each within the scatter of the next); then compound 3; then compound 2.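

Among these compounds, on the sulfur, the identity of the group on the phenyl ring matters more than the earlier compounds could show: a number 61.3 percentage points lower from compound 2 to compound 4 (beyond the scatter) with fluoro in place of methyl on an aromatic carbon, so a 4-substituent alone does not carry the high reading of compound 2. In this assay, 4-fluorophenyl and 3-fluorophenyl cannot be ordered, with a number 8 percentage points higher from compound 1 to compound 4 (within the scatter) on that exchange. Phenethyl also stands apart from 4-fluorophenyl, with a number 17 percentage points lower from compound 3 to compound 4 (beyond the scatter) on that change, so among the groups shown only 4-methylphenyl gives a higher reading than phenethyl.

Going by these compounds, whether a 4-methoxyphenyl, a 4-aminophenyl or a 4-ethylphenyl group on the sulfur would stay near compound 2 or fall towards compound 4 remains open. Nothing measured here accounts for the gap between methyl and fluoro.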